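Working notes on a small hemolysis inhibition series

The source may hold more compounds than are shown below. What is called first, only, known or untested is meant among the compounds shown, and "the series" means these compounds.

Compound 1 `COc1cc(OC)c(OC)cc1/C=C/C(=O)c1cc(OC(C)=O)ccc1OC(C)=O` gives 2.33 ug/mL in a functional assay on cells (Erythrocyte, Rattus norvegicus) for inhibition, read by hemolysis, with a stated time of 1 h; a higher number here means a weaker inhibitor, a lower number a stronger inhibitor. Compound 2 `COc1cc(OC)c(OC)cc1/C=C/C(=O)c1cc(Cl)ccc1O` gives 2.23 ug/mL in this assay, and compound 3 `COc1cc(OC)c(-c2cc(=O)c3cc(O)ccc3o2)cc1OC` gives 2.14 ug/mL in this assay. Compound 2 stands second highest of the three numbers, yet all three values lie within the scatter of one another, so no order among them can be read. Compound 4 `COc1cc(OC)c(OC)cc1/C=C/C(=O)c1ccc(O)cc1O` differs from compound 2 by 2,4-dihydroxyphenyl in place of 5-chloro-2-hydroxyphenyl on a carbonyl carbon. Among the compounds with values here, no step between measured compounds covers this change. With every measured value so close together, the expectation for compound 4 is a step of a 1.0-fold higher number from compound 2 to compound 4 (0.01 log units; within the scatter) that stays within the scatter in this assay. In this assay compound 4 is expected to give 2.3 ug/mL, with an estimated range from 1.2 ug/mL to 4.5 ug/mL.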

Compound 4, half-maximal inhibitory concentration: 2.37 ug/mL
The estimate for compound 4 lay 1.0-fold (0.01 log units) below the measured number, within the range that was stated.
By their numbers in this assay, from the lowest: compounds 3, 2, 1 and 4 (each within the scatter of the next).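

In this assay, within the data shown here, replacing 5-chloro-2-hydroxyphenyl with 2,4-dihydroxyphenyl on the carbonyl carbon gives a 1.1-fold higher number from compound 2 to compound 4 (0.03 log units; within the scatter), the only step between compounds that differ in one place. At this position, the two groups cannot be told apart in this read-out. No evidence on hand bears on this result. From the compounds shown here alone, it remains open whether a phenyl ring carrying an amine or a carboxylic acid at this place would give a step beyond the scatter.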